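Ring substitution on the shared core: trifluoromethoxy next

This account rests on a few compounds, and the source may have more. Where it says the series, first, only, none or still open, it means among the compounds named here.

Measured so far, each in a toxicity assay on L02 cells (Homo sapiens) for cytotoxicity, read by CCK-8 assay, with a stated time of 72 h; on this read-out lower numbers stand for stronger inhibition and higher numbers for weaker inhibition:
compound 1, `CC(C)(C)OC(=O)/C=C1/C(=O)Nc2ccccc21`: 2450 nM
compound 2, `Cc1ccc2c(c1)/C(=C\C(=O)OC(C)(C)C)C(=O)N2`: 2680 nM
compound 3, `CCCCc1ccc2c(c1)/C(=C\C(=O)OC(C)(C)C)C(=O)N2`: 4400 nM

All three share one core and differ only at one aromatic carbon of the six-membered ring. Compound 3, carrying butyl there, sits at the upper end of the three numbers in this assay, yet every step to it is small: a 1.8-fold higher number from compound 1 to compound 3 (0.25 log units; within the scatter) and a 1.6-fold higher number from compound 2 to compound 3 (0.22 log units; within the scatter) are both within the scatter, as is a 1.1-fold higher number from compound 1 to compound 2 (0.04 log units; within the scatter). Nothing in the set so far separates hydrogen, methyl or butyl at that position.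

Compound 4, `CC(C)(C)OC(=O)/C=C1/C(=O)Nc2ccc(OC(F)(F)F)cc21`, is not yet measured. It differs from compound 3 by trifluoromethoxy in place of butyl on an aromatic carbon. Among the measured compounds shown here, the steps that bear on this position are a 1.8-fold higher number from compound 1 to compound 3 (0.25 log units; within the scatter) and a 1.6-fold higher number from compound 2 to compound 3 (0.22 log units; within the scatter), and neither moved the number beyond the scatter; no oxygen- or fluorine-bearing group has been tried at that position, so only these steps guide the expectation. For compound 4 in this assay no step beyond the scatter is expected, which corresponds to a 1.5-fold lower number from compound 3 to compound 4 (0.17 log units; within the scatter). Compound 4 is therefore estimated at 3000 nM, within a range of 1400 nM to 6500 nM.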

Compound 4, half-maximal inhibitory concentration: 4040 nM
The estimate for compound 4 lay 1.3-fold (0.13 log units) below the measured number; measured number inside the range.
By their numbers in this assay, from the lowest: compounds 1, 2, 4 and 3 (each within the scatter of the next).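

In this assay, trifluoromethoxy, the only oxygen- and fluorine-bearing group shown at this aromatic carbon, stays within the scatter of all three earlier substituents, with a 1.1-fold lower number from compound 3 to compound 4 (0.04 log units; within the scatter) and a 1.5-fold higher number from compound 2 to compound 4 (0.18 log units; within the scatter) and a 1.6-fold higher number from compound 1 to compound 4 (0.22 log units; within the scatter) all printed as such. Across compounds 1, 2, 3 and 4, hydrogen, methyl, butyl and trifluoromethoxy are therefore not separated at this position, and none of the four goes against that reading, so the lack of separation now extends beyond hydrocarbon substituents to a group with a hydrogen-bond acceptor. No supporting data bear on why the number stays within the scatter here.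

On these data alone, whether an amine or a carboxylic acid at this aromatic carbon would give a step beyond the scatter remains open. So does the outcome of any such group at another carbon of the shared core.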